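The source may hold more compounds than are shown below. What is called first, only, known or untested is meant among the compounds shown, and "the series" means these compounds.

Measured in a functional assay on DLD-1 cells (Homo sapiens) for antiproliferative activity, read by CellTiter-Glo, with a stated time of 72 h; a lower number here means a stronger inhibitor, a higher number a weaker inhibitor:
Compound 1, `CC1CCN(C2CCN(S(=O)(=O)c3ccc(Cl)nc3)CC2)CC1`, gives 3700 nM.
Compound 2, `COc1cccc(S(=O)(=O)N2CCC(N3CCC(C)CC3)CC2)c1`, gives > 5000 nM, which is a limit of the assay rather than a number.
Compound 3, `CC1CCN(C2CCN(S(=O)(=O)c3ccc(Br)c(Cl)c3)CC2)CC1`, gives 12 nM.

Compound 3 stands lowest of the numbers shown. Its nearest neighbour is compound 1, and the step between them is a 310-fold lower number from compound 1 to compound 3 (2.49 log units; beyond the scatter). Compound 2 sits at the limit of > 5000 nM in this assay, at which 1 of the 3 values shown sits, so only a floor can be stated, an at least 410-fold lower number from compound 2 to compound 3 (2.61 log units; beyond the scatter).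

Compound 4, `CC1CCN(C2CCN(S(=O)(=O)c3cn(C)cn3)CC2)CC1`, keeps the shared core and changes only the group on the sulfonyl sulfur: 1-methyl-1H-imidazol-4-yl in place of 4-bromo-3-chlorophenyl on a sulfonyl sulfur. Going by the values given here, the steps that bear on this are the two just described: each time the 4-bromo-3-chlorophenyl group is exchanged for a smaller or nitrogen-containing aromatic ring, the number rises by a very large margin. Compound 4 carries a five-membered ring with two nitrogens in the same place, so a large rise in this assay is expected, of the order of a 420-fold higher number from compound 3 to compound 4 (2.62 log units; beyond the scatter). Compound 4 is therefore estimated at 5000 nM, with a range from 1500 nM to 20000 nM.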

Compound 4, half-maximal inhibitory concentration: > 5000 nM
Compound 4 gave a limit, no number; the forecaster's own chance of this, stated with the estimate: 50%; the middle value sits exactly at the limit.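

On the sulfonyl sulfur, a five-membered aromatic ring with 2 hetero atoms now joins the six-membered rings of compound 1 and compound 2 at the weak end of this assay: 1-methyl-1H-imidazol-4-yl in place of 4-bromo-3-chlorophenyl gives an at least 410-fold higher number from compound 3 to compound 4 (2.61 log units; beyond the scatter). Against the chloropyridine of compound 1, the same imidazole gives an at least 1.3-fold higher number from compound 1 to compound 4 (0.13 log units; that floor lies within the scatter), a floor too small to separate the two groups. Compound 2 and compound 4 both stop at the assay limit rather than at a number, so the step between them cannot be read: the limit of > 5000 nM in this assay, at which 2 of the 4 values shown sit.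

From the compounds shown here alone, whether a 4-bromophenyl or a 3-chlorophenyl group alone would keep the low number of compound 3 remains open. Going by these compounds, how far the true values of compound 2 and compound 4 lie past the limit also remains open.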